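This account rests on a few compounds, and the source may have more. Where it says the series, first, only, none or still open, it means among the compounds named here.

Compound 1 `N=C(NS(=O)(=O)c1ccccc1)N1CCN(c2cc3c(cc2F)c(=O)c(C(=O)O)cn3C2CC2)CC1` carries a phenyl group on a sulfonyl sulfur, while compound 2 `N=C(NS(=O)(=O)c1ccccc1Cl)N1CCN(c2cc3c(cc2F)c(=O)c(C(=O)O)cn3C2CC2)CC1` and compound 3 `N=C(NS(=O)(=O)c1cccc(Cl)c1)N1CCN(c2cc3c(cc2F)c(=O)c(C(=O)O)cn3C2CC2)CC1` carry 2-chlorophenyl and 3-chlorophenyl in that place. In a functional assay on A549 cells (Homo sapiens) for antiproliferative activity, read by MTT assay, with a stated time of 72 h (on this read-out higher numbers stand for weaker inhibition and lower numbers for stronger inhibition), compound 1 gives 71 nM, compound 2 gives 71 nM and compound 3 gives 71 nM. Compound 3 therefore stands level with the other two.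

Compound 4 `N=C(NS(=O)(=O)c1ccc(C(F)(F)F)cc1)N1CCN(c2cc3c(cc2F)c(=O)c(C(=O)O)cn3C2CC2)CC1` has not yet been measured. It has 4-(trifluoromethyl)phenyl in place of 3-chlorophenyl on a sulfonyl sulfur, a difference counted as 4-(trifluoromethyl)phenyl in place of 3-chlorophenyl on a sulfonyl sulfur.

Within the data shown here, three measured steps bear on this change. Chloro in place of hydrogen on an aromatic carbon gives no change at the digits printed from compound 1 to compound 2 (within the scatter) and also no change at the digits printed from compound 1 to compound 3 (within the scatter). Exchanging 2-chlorophenyl for 3-chlorophenyl gives no change at the digits printed from compound 2 to compound 3 (within the scatter). Among the measured compounds shown here, all three steps are flat, but none of the measured compounds carries a trifluoromethyl group, so the evidence for this particular exchange is indirect.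

On the flat steps among compounds 1, 2 and 3, no shift beyond the scatter is expected in this assay, in either direction. The estimated step is no change at the digits printed from compound 3 to compound 4 (within the scatter). For compound 4 the expected value is 71 nM, with an estimated range from 32 nM to 160 nM.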

Compound 4, half-maximal inhibitory concentration: 71 nM
Compound 4: middle estimate and measured number agree at the digits printed, and the stated range covers the measured number.
By their numbers in this assay, from the lowest: compounds 1, 2, 3 and 4 (each within the scatter of the next).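

In this assay, 4-(trifluoromethyl)phenyl in place of 3-chlorophenyl on a sulfonyl sulfur gives no change at the digits printed from compound 3 to compound 4 (within the scatter), so the flat picture at this position now extends to a group of 10 heavy atoms that carries fluorine rather than chlorine. The comparisons with the other two compounds agree: 4-(trifluoromethyl)phenyl in place of 2-chlorophenyl gives no change at the digits printed from compound 2 to compound 4 (within the scatter), and adding trifluoromethyl to the plain phenyl group gives no change at the digits printed from compound 1 to compound 4 (within the scatter). The earlier compounds had shown this flatness only for chloro in place of hydrogen and for an exchange between two chlorophenyl groups, and no measurement here accounts for the flatness now seen across all four compounds.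

Going by these compounds, whether the position stays this flat with a different kind of group remains open, for example an amine on the phenyl ring, or a longer alkyl chain in place of the phenyl on the sulfonyl sulfur. All four compounds also share the same core, so they leave open how a change elsewhere in the molecule would read in this assay.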